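A Methoxy Takes the Place of the Thiazolyl

A few compounds are considered here, and "the series" means these few. Any claim that something is new, unique, unknown or untested is made for them only; others in the source may bear on it.

Compound 1 `c1cc(-c2nccs2)c2c(c1)C(c1ncc[nH]1)CC2` was tested in a functional assay on CHO cells for agonist activity at Alpha-1D adrenergic receptor (Homo sapiens), read by FLIPR and calcium flux (on this read-out higher numbers stand for an effect only at larger amounts of compound and lower numbers for an effect already at smaller amounts), where compound 1 gives 3190 nM. This is the only full number shown, so compound 1 is the reference point for what follows. Compound 2 `CS(=O)(=O)Nc1c(Cl)ccc2c1CCCC2c1ncc[nH]1` in this assay reaches only > 10000 nM, which is a limit of the assay rather than a number, as the limit of > 10000 nM in this assay, at which 1 of the 2 values shown sits, records. Compound 3 `COc1cccc2c1CCC2c1ncc[nH]1` differs from compound 1 in a single place: methoxy in place of 1,3-thiazol-2-yl on an aromatic carbon. Among the measured compounds shown here, no measured pair shows this exact change, so its effect has to be judged without a direct precedent. The expectation for compound 3 is a step of a 1.6-fold higher number from compound 1 to compound 3 (0.20 log units; within the scatter), leaning toward a somewhat weaker effect but staying close to the edge of the usual scatter. The estimated value for compound 3 is 5000 nM, with a range from 1500 nM to 20000 nM.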

Compound 3, half-maximal effective concentration: > 10000 nM
Compound 3: no number, only a limit (the forecaster's own chance of this, stated with the estimate: 35%); at least 2.0-fold (0.30 log units) between middle value and limit.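

Replacing 1,3-thiazol-2-yl with methoxy on this aromatic carbon gives an at least 3.1-fold higher number from compound 1 to compound 3 (0.49 log units; beyond the scatter), so this position does not tolerate every substituent equally in this assay. The value for compound 3 is a limit of the assay and not a number, and it falls at the same limit as compound 2: the limit of > 10000 nM in this assay, at which 2 of the 3 values shown sit. With the 1,3-thiazol-2-yl group, compound 1 gives a full number, whereas the smaller methoxy group leaves no measurable value, which links a readable effect to the group at this carbon in this single pair.

As far as these compounds go, how far compound 3 lies past its limit remains unknown. One pair also cannot show whether the ring of the 1,3-thiazol-2-yl group matters or only its particular atoms, a question that a phenyl ring or an amine at this carbon could help to answer.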